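The source may report more compounds than this note shows. Statements on the series, on what has been measured and on what is new or still open speak of the compounds shown alone.

Measured compounds:
Compound 1, `O=C(NCCCNc1nc(Nc2cncnc2)ncc1C1CC1)C1CCC1`: 3200 nM
Compound 2, `COCCC(=O)NCCCNc1nc(Nc2cccc(F)c2)ncc1Br`: 60 nM
Compound 3, `CC(C)c1cnc(Nc2cccc(F)c2)nc1NCCCNC(=O)C1CCC1`: > 1000 nM

Of the compounds shown here, three sharing the same core have been tested in an assay on isolated protein for inhibition of serine/threonine-protein kinase TBK1 (Homo sapiens); on this read-out lower numbers stand for stronger inhibition and higher numbers for weaker inhibition. Compound 1 gives 3200 nM, the highest of the two plain numbers shown. Compound 2 gives 60 nM, a much lower number, and the gap between the two is beyond the scatter; compound 2 differs from compound 1 at more than one place, so no single step accounts for it. For compound 3 this assay reports only a limit, > 1000 nM, and not a number (the limit of > 1000 nM in this assay, at which 1 of the 3 values shown sits).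

Compound 4, `CN(C)Cc1ccc(Nc2ncc(C3CC3)c(NCCCNC(=O)C3CCC3)n2)cc1`, is not yet measured. It differs from compound 1 in one place: 4-((dimethylamino)methyl)phenyl in place of pyrimidin-5-yl on a nitrogen on an aromatic ring. Among the compounds with values here, no measured pair isolates this change, so the direction and size of the step can only be expected, not read off. The lower number for compound 2, which carries a phenyl-type ring in the same position, points towards a smaller number for compound 4, but compound 2 also differs elsewhere.

Compound 4 is therefore expected to give about 350 nM in this assay, somewhere between 60 nM and 2000 nM. This estimate means a step of a 9.1-fold lower number from compound 1 to compound 4 (0.96 log units; beyond the scatter) towards stronger inhibition, beyond the scatter but uncertain in size.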

Compound 4, half-maximal inhibitory concentration: 6 nM
The estimate for compound 4 lay 58-fold (1.77 log units) above the measured number; the whole stated range lies above it.
By their numbers in this assay, from the lowest: compound 4; then compound 2; then compound 1.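

Within the data shown here, compound 4 gives the first single-place comparison in this assay, and it shows a large effect: with the rest of the molecule unchanged, replacing pyrimidin-5-yl with 4-((dimethylamino)methyl)phenyl on the aromatic-ring nitrogen gives a 530-fold lower number from compound 1 to compound 4 (2.73 log units; beyond the scatter). Among these compounds, the group at this position alone can therefore shift the read-out far beyond the scatter, which the earlier compounds, differing in more than one place, could not show. Nothing measured here explains why the step is so large.

Going by these compounds, the change replaces the ring and adds the dimethylaminomethyl side chain at once, so the contribution of each remains open. An unsubstituted phenyl ring would separate the two, while a morpholine in place of the dimethylamino group would test whether this particular amine matters.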